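The source may report more compounds than this note shows. Statements on the series, on what has been measured and on what is new or still open speak of the compounds shown alone.

In an ADME assay on KB cells (Homo sapiens) for cytotoxicity, with a stated time of 48 h (on this read-out lower numbers stand for stronger inhibition and higher numbers for weaker inhibition), compound 1 `CC1=CCC[C@](C)(CC/C(C)=C/CC2=C(O)C(=O)C=C(N[C@H](C(=O)O)[C@@H](C)O)C2=O)[C@@H]1C` gives > 10 ug/mL, which is a limit. Compound 2 `CC1=CCC[C@](C)(CC/C(C)=C/CC2=C(O)C(=O)C=C(N[C@H](CO)C(=O)O)C2=O)[C@@H]1C` gives > 10 ug/mL, also a limit. Compound 3 `CC1=CCC[C@](C)(CC/C(C)=C/CC2=C(O)C(=O)C=C(N[C@H](C(=O)O)[C@H](C)O)C2=O)[C@@H]1C` gives > 10 ug/mL, again a limit, so it offers no exact number to start from. Compound 4 `CC1=CCC[C@](C)(CC/C(C)=C/CC2=C(O)C(=O)C=C(NCC(=O)O)C2=O)[C@@H]1C` differs from compound 3 by hydrogen in place of 1-hydroxyethyl on a saturated chain carbon bound to an amine nitrogen and a carbonyl carbon: hydrogen replaces 1-hydroxyethyl, which turns 1-carboxy-2-hydroxypropyl into carboxymethyl. The closest comparison is a step that the two limits leave unreadable from compound 2 to compound 3. The other two comparisons are a step that the two limits leave unreadable from compound 1 to compound 2 and a step that the two limits leave unreadable from compound 1 to compound 3, and none of the three has a readable size because of the limit of > 10 ug/mL in this assay, at which 3 of the 3 values shown sit. No step beyond the usual scatter is therefore expected in this assay, and another limit is likely. The expected step is a step that the limit leaves unreadable from compound 3 to compound 4. Compound 4 is estimated at 14 ug/mL, with an expected range of 7 ug/mL to 30 ug/mL.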

Compound 4, half-maximal inhibitory concentration: 5.4 ug/mL
For compound 4 the middle estimate is 2.6-fold (0.41 log units) above the measured one, and the stated range ends above it.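

In this assay, hydrogen on this saturated chain carbon is the only case shown that gives an exact number, with compound 4 at 5.4 ug/mL. The change reads as an at least 1.8-fold lower number from compound 3 to compound 4 (0.26 log units; that floor lies within the scatter), as an at least 1.8-fold lower number from compound 1 to compound 4 (0.26 log units; that floor lies within the scatter) and as an at least 1.8-fold lower number from compound 2 to compound 4 (0.26 log units; that floor lies within the scatter), and each of these is only a floor, because the starting value is a limit: the limit of > 10 ug/mL in this assay, at which 3 of the 4 values shown sit.

The steps among compound 1, compound 2 and compound 3 cannot be read. As far as these compounds go, the true size of the drop stays open, as does whether a plain methyl group on this carbon would behave like hydrogen or like 1-hydroxyethyl.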